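The compounds below may be only part of what the source reports. "The series", "measured", "known", "first", "only" and "open" are said of these compounds alone.

Compound 1 `C=CC(=C)CC[C@@H]1[C@@]2(C)CCC[C@](C)(COC(=O)/C=C/c3ccc(O)cc3)[C@@H]2CC[C@@]1(C)O` gives 19300 nM in a functional assay on SW480 cells (Homo sapiens) for cytotoxicity, read by MTT assay, with a stated time of 48 h; a higher number here means a weaker inhibitor, a lower number a stronger inhibitor. Among the compounds with values here, compound 2 `C=CC(=C)CC[C@@H]1[C@@]2(C)CCC[C@](C)(COC(=O)/C=C/c3ccc(O)c(OC)c3)[C@@H]2CC[C@@]1(C)O` gives 16900 nM in this assay; of the two numbers so far it stands nearest compound 1, and the step of a 1.1-fold lower number from compound 1 to compound 2 (0.06 log units; within the scatter) is within the scatter. Compound 3 `C=CC(=C)CC[C@@H]1[C@@]2(C)CCC[C@](C)(COC(=O)/C=C\c3ccc(O)c(OC)c3)[C@@H]2CC[C@@]1(C)O` differs from compound 2 only thus: the two compounds have the same atoms and bonds and differ only in configuration as drawn: 1 of 6 stereo elements differ; a double bond is drawn E in compound 2 and Z in compound 3. Within the data shown here, no measured step alters the geometry of a double bond, so the single known step, a 1.1-fold lower number from compound 1 to compound 2 (0.06 log units; within the scatter), does not bear on this change and gives no direction. Therefore no step beyond the scatter is expected, a 1.0-fold higher number from compound 2 to compound 3 (0.00 log units; within the scatter). Compound 3 is estimated at 17000 nM, with a range from 6000 nM to 50000 nM.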

Compound 3, half-maximal inhibitory concentration: 17600 nM
Compound 3: middle estimate off by 1.0-fold (0.02 log units), on the low side; low and high end bracket the measured number.
By their numbers in this assay, from the lowest: compounds 2, 3 and 1 (each within the scatter of the next).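

In this assay, the double bond tolerates either drawn geometry, with E and Z forms not separated (a 1.0-fold higher number from compound 2 to compound 3 (0.02 log units; within the scatter)). Taken alone, the methoxy-bearing Z form also stays unseparated from the 2-(4-hydroxyphenyl)ethenyl ester (a 1.1-fold lower number from compound 1 to compound 3 (0.04 log units; within the scatter)). Within the data shown here, this comparison isolates geometry as the only change: the fact that compounds 2 and 3 differ only in the configuration as drawn.

From the compounds shown here alone, whether an amide in place of the ester, or an amine or a carboxylic acid on the aromatic ring, would move the number stays open. So does whether any change at this position reaches beyond the scatter.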